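Swapping the Carboxycyclohexyl Ring for a Dioxothianyl Ring

The source may report more compounds than this note shows. Statements on the series, on what has been measured and on what is new or still open speak of the compounds shown alone.

Compound 1, `C[C@]1(C(=O)N2CC[C@](c3ccc(C(F)(C(F)(F)F)C(F)(F)F)cc3)(S(=O)(=O)c3ccc(F)cc3)C2)CC[C@@H](C(=O)O)CC1`, is one of two measured members of this series. In an ADME assay on microsomes from liver (Mus musculus) for metabolic stability, with a stated time of 10 min (a lower number here means that less of the compound is left, a higher number that more of the compound is left), compound 1 gives 100%, and compound 2, `NC(=O)[C@H]1CC[C@H](C(=O)N2CC[C@](c3ccc(C(F)(C(F)(F)F)C(F)(F)F)cc3)(S(=O)(=O)c3ccc(F)cc3)C2)CC1`, gives 100% in this assay. Among the measured compounds shown here, the only measured step, no change at the digits printed from compound 1 to compound 2 (within the scatter), lies within the usual scatter, so compound 1 stands level with compound 2 and neither can be called more stable than the other.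

Compound 3, `CCC1(C(=O)N2CC[C@](c3ccc(C(F)(C(F)(F)F)C(F)(F)F)cc3)(S(=O)(=O)c3ccc(F)cc3)C2)CCS(=O)(=O)CC1`, is not yet measured. It differs from compound 1 by 4-ethyl-1,1-dioxothian-4-yl in place of 4-carboxy-1-methylcyclohexyl on a carbonyl carbon. For the measured compounds named here, the change from compound 1 to compound 2 also touched the 4-carboxy-1-methylcyclohexyl group and produced no step beyond the scatter, which is the only guide here; the new group in compound 3 has not been tested in any neighbour. A small step down or none is therefore expected, a number 10 percentage points lower from compound 1 to compound 3 (within the scatter), and compound 3 is estimated at 90% in this assay, between 70% and 100%.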

Compound 3, percent of the compound remaining: 0%
The estimate for compound 3 lay 90 percentage points above the measured number; the whole stated range lies above it.
By their numbers in this assay, from the lowest: compound 3; then compounds 1 and 2 (each within the scatter of the next).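

In this assay, 4-ethyl-1,1-dioxothian-4-yl on the carbonyl carbon gives a number 100 percentage points lower from compound 1 to compound 3 (beyond the scatter), and the comparison with the amide gives a number 100 percentage points lower from compound 2 to compound 3 (beyond the scatter). Among the compounds shown here, the earlier step, no change at the digits printed from compound 1 to compound 2 (within the scatter), showed no such effect, so compound 3 is the first sign that the group at this place can decide how much compound remains in this assay. Nothing available explains this drop.

The change alters several things at once, including the ring sulfur with its two oxygens, the ethyl chain and the loss of the carboxylic acid, and the compounds shown do not separate them. On these data alone, it remains open whether 4-ethyl-1,1-dioxothian-4-yl with methyl in place of its ethyl, or 4-carboxy-1-methylcyclohexyl with ethyl in place of its methyl, would behave like compound 1 or compound 3.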